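This account rests on a few compounds, and the source may have more. Where it says the series, first, only, none or still open, it means among the compounds named here.

Working notes on the series. Compound 1 `c1ccc(C(/N=C2\CCCCN2)C2CC2)cc1`, compound 2 `c1ccc(C(/N=C2\CCCCCN2)C2CC2)cc1` and compound 3 `c1ccc(C(/N=C2\CCCCCCN2)C2CC2)cc1` share one core and differ only in the size of a single saturated ring. In a functional assay on the whole organism (plasma, strain Sprague-Dawley) with Rattus norvegicus as the target, with a stated time of 2 h, at a dose of 12.5 mg/kg by the oral route (on this read-out lower numbers stand for a weaker effect and higher numbers for a stronger effect at the one dose given), compound 1 gives 1%, compound 2 gives 5% and compound 3 gives 0%. Compound 2 carries the largest of the three numbers, yet its gaps to compound 1 and to compound 3 both fall within the scatter, so the three cannot be told apart on this assay and all of them sit near the floor of the read-out.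

Compound 4 `COc1ccc(C(/N=C2\CCCCCN2)C2CC2)cc1` is the next variation on compound 2: methoxy in place of hydrogen on an aromatic carbon. Among the measured compounds shown here, no measured pair in the set shows the effect of any substituent on this aromatic ring, so there is no step to lean on. With compound 2 giving 5% and the whole set lying close to zero, no step beyond the scatter is expected in either direction. For compound 4 the expected step is no change at the digits printed from compound 2 to compound 4 (within the scatter), essentially none. Compound 4 is estimated at 5%, with a range from 0% to 15%.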

Compound 4, a percentage reported as inhibition, in the whole organism at one dose (the size of the read-out at that dose, not a potency): 1%
The estimate for compound 4 lay 4 percentage points above the measured number; measured number inside the range.
By their numbers in this assay, from the lowest: compounds 3, 1, 4 and 2 (each within the scatter of the next).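

Methoxy in place of hydrogen on an aromatic carbon, para to a large group, gives the first reading on any substituent at this ring. In this assay the step is a number 4 percentage points lower from compound 2 to compound 4 (within the scatter) and so does not separate the two compounds, which leaves compound 4 indistinguishable from the unsubstituted compounds on this read-out, with the whole set still near its floor. Nothing at hand speaks to the reason for this result.

Going by these compounds, whether an amine, a carboxylic acid or a longer chain at this place would give a number clear of the scatter remains open. Also open, on these data alone, is whether methoxy would behave the same way on the ring sizes of compound 1 and compound 3.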